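This account rests on a few compounds, and the source may have more. Where it says the series, first, only, none or still open, it means among the compounds named here.

The compounds measured in a physicochemical assay for lipophilicity; a higher number here means a more lipophilic compound, a lower number a more polar compound:
compound 1 `CCC(C)OC(=O)/C=C(C)/C=C/CC(C)CCCC(C)C` gives 7.69;
compound 2 `CCCCOC(=O)/C=C(C)/C=C/CC(C)CCCC(C)(C)OC` gives 6.62;
compound 3 `CCC(C)OC(=O)/C=C(C)/C=C/CC(C)CCCC(C)(C)OC` gives 6.49.

Compound 1 stands highest of the three, beyond the scatter from both others. Compound 4 `CC(/C=C/CC(C)CCCC(C)C)=C\C(=O)NCC(C)C` is not yet measured; it differs from compound 1 in one place: isobutylamino in place of sec-butoxy on a carbonyl carbon. Neither measured step matches this change. The step of a number 1.20 log units lower from compound 1 to compound 3 (beyond the scatter) adds a methoxy on a saturated chain carbon bound to three saturated chain carbons, and the step of a number 0.13 log units lower from compound 2 to compound 3 (within the scatter) reshapes only the alkyl on the oxygen next to the carbonyl group. Because a number 0.13 log units lower from compound 2 to compound 3 (within the scatter) stayed within the scatter, the alkyl alone offers no guidance, so the expectation rests on the exchange of sec-butoxycarbonyl for isobutylcarbamoyl, which is expected to lower the number. Compound 4 is therefore estimated at 6.4, between 5.7 and 7.1. The expected step is a number 1.29 log units lower from compound 1 to compound 4 (beyond the scatter).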

Compound 4, partition coefficient: 6.19
Compound 4: middle estimate off by 0.21 log units, on the high side; the measured number falls inside the stated range.
By their numbers in this assay, from the lowest: compounds 4, 3 and 2 (each within the scatter of the next, the first and the last beyond it); then compound 1.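

In this assay the group on the carbonyl carbon proves to matter: a number 1.50 log units lower from compound 1 to compound 4 (beyond the scatter) when isobutylamino replaces sec-butoxy. Reshaping the alkyl on the oxygen had stayed within the scatter, whereas this exchange, with the same count of heavy atoms, brings nitrogen and its hydrogen in place of oxygen and gives a large step. Nothing measured here accounts for the step. Since the alkyl changes shape too, the effect of the nitrogen itself remains unseparated; sec-butylamino on the same core would isolate it. As far as these compounds go, how the isobutylamino change combines with the methoxy on the saturated chain also remains open.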